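The source may hold more compounds than are shown below. What is called first, only, known or untested is meant among the compounds shown, and "the series" means these compounds.

Compound 3 `CNC(=O)c1cc(Oc2ccc3oc(Nc4cccc(C(F)(F)F)c4)nc3c2)ccn1` stands in an ADME assay on Caco-2 cells (Homo sapiens) for permeability, in the apical to basolateral direction (a higher number here means that the compound crosses the layer faster, a lower number that the compound crosses the layer more slowly), at 10 10^-6 cm/s. Compound 1 `CNC(=O)c1cc(Oc2ccc3sc(Nc4cccc(C(C)(C)C)c4)nc3c2)ccn1` gives 10 10^-6 cm/s in this assay, and compound 2 `CCc1ccccc1Nc1nc2cc(Oc3ccnc(C(=O)NC)c3)ccc2o1` gives 10 10^-6 cm/s, so the three measured compounds sit level with one another within the scatter. Going by the values given here, the one measured step between neighbours, 3-(trifluoromethyl)phenyl in place of 2-ethylphenyl on a nitrogen on an aromatic ring, gave no change at the digits printed from compound 2 to compound 3 (within the scatter). Compound 4 `CNC(=O)c1cc(Oc2ccc3oc(Nc4ccc(Br)cc4)nc3c2)ccn1` has not yet been measured. It differs from compound 3 by 4-bromophenyl in place of 3-(trifluoromethyl)phenyl on a nitrogen on an aromatic ring. Among the compounds with values here, the step from compound 2 to compound 3 is the only measured step that bears on this change, since it also exchanges one substituted phenyl for another on a nitrogen on an aromatic ring, and it stayed within the scatter; the three measured compounds give no sign that the choice of that phenyl moves the read-out. For compound 4 the expected step is therefore no change at the digits printed from compound 3 to compound 4 (within the scatter), none beyond the scatter. Compound 4 is estimated at 10 10^-6 cm/s, with a range from 5 10^-6 cm/s to 20 10^-6 cm/s.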

Compound 4, apparent permeability: 10 10^-6 cm/s
Beside the measured number, compound 4's estimate shows no gap at the digits printed; measured number inside the range.
By their numbers in this assay, from the lowest: compounds 1, 2, 3 and 4 (each within the scatter of the next).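

In this assay, 4-bromophenyl in place of 3-(trifluoromethyl)phenyl on a nitrogen on an aromatic ring gave no change at the digits printed from compound 3 to compound 4 (within the scatter) and, set against the ethyl-bearing group, 4-bromophenyl in place of 2-ethylphenyl gave no change at the digits printed from compound 2 to compound 4 (within the scatter) as well. The position has now held three differently substituted phenyl groups, named with their substituents at the 2, 3 and 4 places, and compounds 2, 3 and 4 stay level, which a single step could not show. Nothing on hand offers a reason for this level read-out.

Going by these compounds, all three groups are substituted phenyls without a charge, so the position remains untested with a phenyl carrying an amine or a carboxylic acid. On these data alone, a longer alkyl chain on that nitrogen in place of the phenyl ring also remains open.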